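This account rests on a few compounds, and the source may have more. Where it says the series, first, only, none or still open, it means among the compounds named here.

Within the data shown here, in a functional assay on Huh-7 cells (Homo sapiens) for inhibition, read by CCK-8 assay, with a stated time of 72 h (on this read-out lower numbers stand for stronger inhibition and higher numbers for weaker inhibition), compound 2 `O=C(/C=C/c1cccnc1)NCCCCCCc1cccc(S(=O)(=O)Nc2ccccc2)c1` gives 2.82 nM and stands lowest of the three numbers so far. Compound 3 `O=C(/C=C/c1cccnc1)NCCCCCCCc1cccc(S(=O)(=O)Nc2ccccc2)c1` at 138 nM and compound 1 `O=C(/C=C/c1cccnc1)NCCCCCCCc1ccc(S(=O)(=O)Nc2ccccc2)cc1` at 1230 nM both lie beyond the scatter from it. Compound 4 `CC(C)(C)c1ccc(NS(=O)(=O)c2cccc(CCCCCCNC(=O)/C=C/c3cccnc3)c2)cc1` differs from compound 2 by tert-butyl in place of hydrogen on an aromatic carbon and so carries 4-(tert-butyl)phenyl where compound 2 has phenyl. Among the measured compounds shown here, no measured pair isolates a change at this place, so the expectation is loose. In this assay a moderately higher number is expected, estimated as a 4.3-fold higher number from compound 2 to compound 4 (0.63 log units; beyond the scatter) and beyond the scatter. The estimate for compound 4 is 12 nM (expected range 1.5 nM to 100 nM).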

Compound 4, half-maximal inhibitory concentration: 163 nM
The estimate for compound 4 lay 14-fold (1.13 log units) below the measured number; the measured number lies above the stated range.
By their numbers in this assay, from the lowest: compound 2; then compounds 3 and 4 (each within the scatter of the next); then compound 1.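

In this assay tert-butyl in place of hydrogen on the aromatic carbon para to a large group gives a 58-fold higher number from compound 2 to compound 4 (1.76 log units; beyond the scatter), so this end of compound 2 does not take the change without a large loss. Among these compounds, the earlier compounds all carry unsubstituted phenyl here, which makes this the first reading at this position. Nothing on hand accounts for the size of the step.

Open, as far as these compounds go, is whether methyl, methoxy or chlorine at the same place would give a smaller step, or whether any replacement of this hydrogen costs as much.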